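This account rests on a few compounds, and the source may have more. Where it says the series, first, only, none or still open, it means among the compounds named here.

Measured in an ADME assay on BEAS-2B cells (Homo sapiens) for cytotoxicity, read by MTT assay, with a stated time of 72 h; on this read-out lower numbers stand for stronger inhibition of growth and higher numbers for weaker inhibition of growth:

- compound 1, `COc1ccc(OC(=O)Nc2ccc([Se]C#N)cc2)cc1`: 25200 nM
- compound 2, `CC(C)COC(=O)Nc1ccc([Se]C#N)cc1`: 26900 nM
- compound 3, `N#C[Se]c1ccc(NC(=O)Oc2ccc(Cl)cc2)cc1`: 9300 nM

Compound 3 gives the lowest number of the three. The nearest is compound 1, and the value of compound 2 lies slightly further from compound 3 than that of compound 1 does; the two higher values sit close to each other. For the measured compounds named here, the only single-point step among the measured compounds runs from compound 1 to compound 3, a 2.7-fold lower number from compound 1 to compound 3 (0.43 log units; beyond the scatter): chloro in place of methoxy on the aromatic carbon of the phenyl carbamate.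

Compound 4, `N#C[Se]c1ccc(NC(=O)Oc2ccccc2)cc1`, differs from compound 3 by hydrogen in place of chloro on an aromatic carbon. Going by the values given here, no measured step puts hydrogen at this position. The expectation rests on the step from compound 1 to compound 3 alone, where chloro gave the lower number and both other substituents gave values in a narrow band above it. Removing the chloro is therefore expected to move the number back up, most likely by a modest amount, a 1.7-fold higher number from compound 3 to compound 4 (0.24 log units; within the scatter); compound 4 is estimated at 16000 nM, in the range 7000 nM to 35000 nM.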

Compound 4, concentration for 50% growth inhibition: 8900 nM
For compound 4 the middle estimate is 1.8-fold (0.25 log units) above the measured one; the measured number falls inside the stated range.
By their numbers in this assay, from the lowest: compounds 4 and 3 (each within the scatter of the next); then compounds 1 and 2 (each within the scatter of the next).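

In this assay the step to hydrogen at this position, para to a large group, reads a 1.0-fold lower number from compound 3 to compound 4 (0.02 log units; within the scatter) and so does not separate chloro from hydrogen; the low number of compound 3 does not depend on the chloro. Hydrogen in place of methoxy reads a 2.8-fold lower number from compound 1 to compound 4 (0.45 log units; beyond the scatter) and shows that, of the three phenyl carbamates, methoxy alone stands apart, with no gain to credit to chloro. Phenyl in place of isobutyl on the oxygen next to a carbonyl group reads a 3.0-fold lower number from compound 2 to compound 4 (0.48 log units; beyond the scatter) and gives the first direct reading of the group on that oxygen.

Open: whether an amine or a carboxylic acid at this ring position, or a longer chain on the carbamate oxygen, would move the number. No data at hand explain any of these differences.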